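The source may hold more compounds than are shown below. What is called first, only, known or untested is meant among the compounds shown, and "the series" means these compounds.

Compound 2 `COc1ccc(-c2cc3ccc(OC)cc3nc2Nc2ccc(NC(=O)CN3CCCCC3)cc2)cc1` carries the highest of the two numbers measured in a functional assay on HUVEC cells (Homo sapiens) for antiproliferative activity, read by MTT assay, with a stated time of 48 h (a higher number here means a weaker inhibitor, a lower number a stronger inhibitor), giving 23500 nM; its nearest neighbour, compound 1 `COc1ccc(-c2cc3ccc(OC)cc3nc2Nc2ccc(NC(=O)CN(C)C)cc2)cc1`, gives 9200 nM in this assay, and the step of a 2.6-fold higher number from compound 1 to compound 2 (0.41 log units; beyond the scatter) is the only measured one. Compound 3 `COc1ccc(-c2cc3ccc(OC)cc3nc2Nc2ccc(NC(=O)CN3CCN(C)CC3)cc2)cc1` differs from compound 2 by 4-methylpiperazin-1-yl in place of piperidin-1-yl on a saturated chain carbon bound to a carbonyl carbon. For the measured compounds named here, no measured step covers this exchange, so only the scale of the one known step guides the expectation. Compound 3 is therefore expected to land near compound 2, with the step of a 1.6-fold lower number from compound 2 to compound 3 (0.19 log units; within the scatter) estimated as small. The estimate for compound 3 is 15000 nM, within 6000 nM to 40000 nM.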

Compound 3, half-maximal inhibitory concentration: 7400 nM
Compound 3: the middle estimate sits 2.0-fold (0.31 log units) above what was measured; measured number inside the range.
By their numbers in this assay, from the lowest: compounds 3 and 1 (each within the scatter of the next); then compound 2.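

In this assay, 4-methylpiperazin-1-yl in place of piperidin-1-yl on a saturated chain carbon bound to a carbonyl carbon gives a 3.2-fold lower number from compound 2 to compound 3 (0.50 log units; beyond the scatter) and so shows that this position separates two six-membered rings. With 4-methylpiperazin-1-yl in place of dimethylamino the result is a 1.2-fold lower number from compound 1 to compound 3 (0.09 log units; within the scatter) within the scatter, so a ring here does not by itself raise the number. Nothing available explains the difference between these two rings. Morpholin-4-yl remains open at this position, as does a longer chain carrying 4-methylpiperazin-1-yl.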